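The source may report more compounds than this note shows. Statements on the series, on what has been measured and on what is new or still open speak of the compounds shown alone.

In an in vitro ADME assay on microsomes from liver (Homo sapiens) for metabolic stability (a higher number here means faster removal of the compound, a lower number slower removal), compound 1 `CC(O)(c1ccc(Cl)cc1)c1nc2ccccc2s1` stands at > 200 mL.min-1.g-1, which is a limit of the assay and not a number. For the measured compounds named here, the only actual number so far comes from its relative, compound 2 `Cc1ccc(C(C)(O)c2nc3ccccc3s2)c(C)c1`, at 396 mL.min-1.g-1. Compound 3 `CC(O)(c1nc2ccccc2s1)c1ccc(Cl)cc1Cl` keeps the core of compound 1 and makes one change, a chloro in place of hydrogen on an aromatic carbon. Going by the values given here, no measured pair shows what such a swap does, so the expected step, a step that the limit leaves unreadable from compound 1 to compound 3, is none beyond the scatter. For compound 3 the estimated value is 300 mL.min-1.g-1, with an expected range from 140 mL.min-1.g-1 to 600 mL.min-1.g-1.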

Compound 3, intrinsic clearance in microsomes: 66 mL.min-1.g-1
Beside the measured number, compound 3's estimate is 4.5-fold (0.66 log units) above it; measured number outside the range, below it.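

In this assay, a chloro in place of hydrogen on an aromatic carbon, ortho to a large group and meta to a chloro group, gives an at least 3.0-fold lower number from compound 1 to compound 3 (0.48 log units; beyond the scatter). Compound 1 stands at > 200 mL.min-1.g-1, which is a limit and not a number. The true size of the step stays unknown because one of its ends is that limit: the limit of > 200 mL.min-1.g-1 in this assay, at which 1 of the 3 values shown sits.

The compounds shown leave open whether a fluoro, a methoxy or an amine in this same place would also lower the number. A single pair cannot say whether chloro would do the same in another compound.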